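Swapping 4-bromophenyl for 1H-indol-3-yl in compound 1

This account rests on a few compounds, and the source may have more. Where it says the series, first, only, none or still open, it means among the compounds named here.

Of the compounds shown here, three have been measured in a functional assay on DU-145 cells (Homo sapiens) for inhibition, read by trypan blue exclusion, with a stated time of 96 h; on this read-out higher numbers stand for weaker inhibition of growth and lower numbers for stronger inhibition of growth. Compound 1 (`Cc1ccc(CS(=O)(=O)/C(=C/c2ccc(Br)cc2)C(=O)c2ccc(Cl)cc2)cc1`) gives 25000 nM, the highest number of the three and so the weakest inhibition of growth. Compound 3 (`COc1ccc(/C=C(\C(=O)c2ccc(Br)cc2)S(=O)(=O)c2ccc(Br)cc2)c(F)c1`) gives 10000 nM, and compound 2 (`O=C(/C(=C\c1ccc(Br)cc1)Sc1ccccc1Br)c1ccc(Br)cc1`) gives 1000 nM. Both gaps from compound 1 lie beyond the usual scatter.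

The unmeasured compound 4 (`Cc1ccc(CS(=O)(=O)/C(=C/c2c[nH]c3ccccc23)C(=O)c2ccc(Cl)cc2)cc1`) keeps the core of compound 1 but carries 1H-indol-3-yl in place of 4-bromophenyl on a double-bonded chain carbon bound to a double-bonded chain carbon. Among the measured compounds shown here, no measured pair isolates this change, so any forecast is uncertain. Compound 1 stands at the top of the measured range at 25000 nM, so a modest move toward stronger inhibition is expected in this assay, somewhat beyond the scatter. The expected step is a 3.1-fold lower number from compound 1 to compound 4 (0.49 log units; beyond the scatter). Compound 4 is estimated at 8000 nM, with an expected range of 2000 nM to 30000 nM.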

Compound 4, concentration for 50% growth inhibition: 25000 nM
Compound 4: the middle estimate sits 3.1-fold (0.49 log units) below what was measured; low and high end bracket the measured number.
By their numbers in this assay, from the lowest: compound 2; then compound 3; then compounds 1 and 4 (each within the scatter of the next).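

In this assay, among the compounds shown here, placing 1H-indol-3-yl in place of 4-bromophenyl on a double-bonded chain carbon bound to a double-bonded chain carbon gives no change at the digits printed from compound 1 to compound 4 (within the scatter), the first direct reading of any change at this position. On the core of compound 1, the position therefore accepts a five-membered aromatic ring and a hydrogen-bond donor, along with the loss of bromine, without a difference beyond the scatter, and both compounds remain at the weak end of the measured set. No measurement at hand explains why the two groups read alike.

From the compounds shown here alone, it remains open whether a group of another kind at this position, such as a carboxylic acid or an amine, would separate from these two. Also open, going by these compounds, is whether the same exchange would read alike on the core of compound 2, which carries a thioether in place of the sulfonyl link.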